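Shifting the fluorine on the ring nitrogen substituent

The source may hold more compounds than are shown below. What is called first, only, known or untested is meant among the compounds shown, and "the series" means these compounds.

Compound 1 `CCN1C(=O)CSC1c1cccc(C(=O)NCCCCc2ccccc2)c1` gives 13% in a functional assay on U2OS cells (Homo sapiens) for inhibition, read by CCK-8 assay, with a stated time of 72 h, tested at 1 uM; on this read-out higher numbers stand for more inhibition at the one concentration tested (going by the name of the read-out) and lower numbers for less inhibition.
Compound 2 `O=C(NCCCCc1ccccc1)c1cccc(C2SCC(=O)N2c2cccc(F)c2)c1` gives 39% in this assay.

Compound 2 stands highest of the two measured compounds, the step being a number 26 percentage points higher from compound 1 to compound 2 (beyond the scatter). Compound 3 `O=C(NCCCCc1ccccc1)c1cccc(C2SCC(=O)N2c2ccccc2F)c1` differs from compound 2 by 2-fluorophenyl in place of 3-fluorophenyl on an amide-type nitrogen in a ring. For the measured compounds named here, the one measured step, a number 26 percentage points higher from compound 1 to compound 2 (beyond the scatter), concerns a different change, so no measured step bears directly on this one. Compound 3 is therefore expected to show no step beyond the scatter, a number 4 percentage points lower from compound 2 to compound 3 (within the scatter). The value of compound 3 in this assay is estimated at 35%, within a range from 15% to 55%.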

Compound 3, a percentage reported as inhibition, at one concentration (the size of the read-out at that concentration, not a potency): 38%
Compound 3: middle estimate off by 3 percentage points, on the low side; the measured number falls inside the stated range.
By their numbers in this assay, from the lowest: compound 1; then compounds 3 and 2 (each within the scatter of the next).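

In this assay replacing 3-fluorophenyl with 2-fluorophenyl on the amide-type nitrogen gives a number 1 percentage points lower from compound 2 to compound 3 (within the scatter) and so shows no measurable effect of where the fluorine sits on this phenyl. Against the ethyl group, 2-fluorophenyl gives a number 25 percentage points higher from compound 1 to compound 3 (beyond the scatter) and so the gain is shared by both fluorophenyl groups, not held by 3-fluorophenyl alone. Nothing available explains why the two fluorophenyl groups read alike.

From the compounds shown here alone, whether the fluorine contributes to the gain or the phenyl ring alone carries it stays open. So does the effect of a chlorine or a methoxy group on that phenyl.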